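Acyl sulfonamide in place of propanoic acid on the benzyl arm

The compounds below may be only part of what the source reports. "The series", "measured", "known", "first", "only" and "open" are said of these compounds alone.

Measured compounds:
compound 1, `CC(C)c1onc(-c2c(Cl)cccc2Cl)c1COc1ccc(N(C)C(=O)c2cccc(C(=O)O)c2)c(C(F)(F)F)n1`, 35%
compound 2, `CC(C)c1onc(-c2c(Cl)cccc2Cl)c1COc1ccc(N(C)Cc2ccc(CCC(=O)O)cc2)c(C(F)(F)F)n1`, 55%

In a functional assay on HEK293 cells for agonist activity at Bile acid receptor (Homo sapiens) (a higher number here means a larger maximal response, a lower number a smaller maximal response), compound 2 gives the higher of the two numbers; compound 1 sits a number 20 percentage points higher from compound 1 to compound 2 (beyond the scatter). That one step alters both the link to the nitrogen and the acid-bearing group, so it is not a direct model for what follows.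

Compound 3, `CC(C)c1onc(-c2c(Cl)cccc2Cl)c1COc1ccc(N(C)Cc2ccc(C(=O)NS(C)(=O)=O)cc2)c(C(F)(F)F)n1`, keeps the benzyl link of compound 2 and changes only the acid end: (methylsulfonyl)carbamoyl in place of 2-carboxyethyl on an aromatic carbon. For the measured compounds named here, no measured pair varies this position alone, so there is no step to scale from; the only anchor is the value of compound 2 in this assay. Without such a step, the expectation for compound 3 is a step of a number 5 percentage points lower from compound 2 to compound 3 (within the scatter), that is no change beyond the scatter, with the range widened to cover a drop.

Compound 3 is therefore estimated at 50% in this assay, between 30% and 72%.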

Compound 3, largest response reached (reported as efficacy), in percent of the reference or control that the assay uses: 64%
Estimate against measurement, compound 3: 14 percentage points below; low and high end bracket the measured number.
By their numbers in this assay, from the lowest: compound 1; then compounds 2 and 3 (each within the scatter of the next).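

In this assay, the benzyl arm accepts (methylsulfonyl)carbamoyl in place of 2-carboxyethyl, giving a number 9 percentage points higher from compound 2 to compound 3 (within the scatter), so this position does not show a change in maximal response beyond the usual scatter for this replacement. Compound 1 and compound 2 both carry a carboxylic acid, whereas compound 3 shows that a response of this size does not depend on one at this end of the arm, at least in this single pair. No available measurement explains this outcome.

Open, from the compounds shown here alone, is whether a carboxylic acid or a tetrazole attached directly to the same aromatic carbon would match this response, which would separate the shorter attachment from the change of acid-bearing group. Also open, going by these compounds, is whether (methylsulfonyl)carbamoyl would give a similar result on a carbonyl-linked arm like that of compound 1.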